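From Fluoro to Methoxy on the Aromatic Carbon

The source may hold more compounds than are shown below. What is called first, only, known or untested is meant among the compounds shown, and "the series" means these compounds.

Compound 1 `CCN(C/C=C/C#CC(C)(C)C)Cc1cccc(OC[Si](C)(C)c2ccc(F)cc2)c1` is one of three compounds tested in a functional assay on liver (Sus scrofa) for inhibition of squalene monooxygenase (Homo sapiens), using microsomes; on this read-out lower numbers stand for stronger inhibition and higher numbers for weaker inhibition; there compound 1 gives 60 nM, the lowest number of the three. Compound 2 `CCN(C/C=C/C#CC(C)(C)C)Cc1cccc(OC[Si](C)(C)c2ccc(Cl)cc2)c1` gives 400 nM, which is a 6.7-fold higher number from compound 1 to compound 2 (0.82 log units; beyond the scatter). Compound 3 `CCN(C/C=C/C#CC(C)(C)C)Cc1cccc(OC[Si](C)(C)c2ccc(C)cc2)c1` gives 120 nM, and a 2.0-fold higher number from compound 1 to compound 3 (0.30 log units; within the scatter) stays within the scatter. Compound 4 `CCN(C/C=C/C#CC(C)(C)C)Cc1cccc(OC[Si](C)(C)c2ccc(OC)cc2)c1` differs from compound 1 by methoxy in place of fluoro on an aromatic carbon. For the measured compounds named here, no measured compound carries a methoxy, so the two steps that replace the fluoro bear only loosely on this one: a 6.7-fold higher number from compound 1 to compound 2 (0.82 log units; beyond the scatter) was modest, while a 2.0-fold higher number from compound 1 to compound 3 (0.30 log units; within the scatter) was within the scatter. A small rise in the number is therefore expected in this assay, and compound 4 is estimated at 130 nM, between 45 nM and 400 nM, so that a 2.2-fold higher number from compound 1 to compound 4 (0.34 log units; beyond the scatter) is expected.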

Compound 4, half-maximal inhibitory concentration: 870 nM
Compound 4: the middle estimate sits 6.7-fold (0.83 log units) below what was measured; measured number outside the range, above it.
By their numbers in this assay, from the lowest: compounds 1 and 3 (each within the scatter of the next); then compound 2; then compound 4.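

This position tolerates methoxy far less well than the earlier changes suggested: in this assay, replacing fluoro gives a 15-fold higher number from compound 1 to compound 4 (1.16 log units; beyond the scatter), the largest step among these compounds. Methoxy also loses to the other two groups, with a 7.3-fold higher number from compound 3 to compound 4 (0.86 log units; beyond the scatter) and a 2.2-fold higher number from compound 2 to compound 4 (0.34 log units; beyond the scatter), which leaves compound 4 the weakest inhibitor of the four. No evidence here accounts for this loss. From the compounds shown here alone, whether it goes with the oxygen of methoxy or simply with a longer group remains open. An ethyl or a hydroxyl group at this place would help separate the two.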